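The source may hold more compounds than are shown below. What is called first, only, known or untested is meant among the compounds shown, and "the series" means these compounds.

The four compounds share one core and differ in the group carried on the sulfonyl sulfur and in where the sulfonamide is attached. Compound 1 is `O=S(=O)(Nc1ccc(-c2nc3ccccc3o2)cc1)c1cccs1`, compound 2 is `COc1ccccc1S(=O)(=O)Nc1ccc2oc(-c3ccccc3)nc2c1`, compound 3 is `O=S(=O)(Nc1ccc(-c2nc3ccccc3o2)cc1)c1cccc(C(F)(F)F)c1`, and compound 4, still unmeasured, is `CS(=O)(=O)Nc1ccc2oc(-c3ccccc3)nc2c1`. In an ADME assay on HEK293 cells (Homo sapiens) for cytotoxicity, read by resazurin assay, with a stated time of 48 h (a lower number here means that less compound is tolerated, a higher number that more compound is tolerated), compound 2 gives 41000 nM. For compound 1 this assay reports only a limit, > 100000 nM. For compound 3 this assay likewise reports only a limit, > 100000 nM. Among the measured compounds shown here, compound 2 is thus the one compound that yields an actual number, while the other two sit at the limit of > 100000 nM in this assay, at which 2 of the 3 values shown sit.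

Compound 4 differs from compound 2 by methyl in place of 2-methoxyphenyl on a sulfonyl sulfur. For the measured compounds named here, no step between two measured compounds is available to show how large an effect such a change has in this assay. Going by the values given here, with compound 2 as the only compound returning a number, the replacement of a large aromatic group by a single-carbon group is expected to move the value upward, toward or past the edge of what this assay can report. The step from compound 2 to compound 4 is expected to be a 2.0-fold higher number from compound 2 to compound 4 (0.29 log units; within the scatter). Compound 4 is therefore estimated at 80000 nM, within a range from 30000 nM to 200000 nM.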

Compound 4, half-maximal cytotoxic concentration: > 100000 nM
Compound 4 ended at the assay's limit (the forecaster's own chance of this, stated with the estimate: 45%); middle value at least 1.2-fold (0.09 log units) away from the limit.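

In this assay, putting methyl in place of 2-methoxyphenyl on a sulfonyl sulfur gives an at least 2.4-fold higher number from compound 2 to compound 4 (0.38 log units; beyond the scatter). Among the compounds shown here, this is the first step between two measured compounds, and it shows that the group at this place can change how much compound the cells tolerate, by more than the usual scatter of repeated measurements. The step is only a minimum and not a full size because compound 4 gives only a limit: the limit of > 100000 nM in this assay, at which 3 of the 4 values shown sit.

What the compounds shown leave open is which part of the change matters: the methoxy group, the aromatic ring, or simply the number of atoms that leave, since a plain phenyl, an ethyl or a longer carbon chain on the same sulfur would be needed to separate these. Compound 1 and compound 3 differ from compound 2 in more than one place, so they cannot settle this question.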